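The compounds below may be only part of what the source reports. "The series", "measured", "known", "first", "only" and "open" are said of these compounds alone.

In a functional assay on A549 cells (Homo sapiens) for cytotoxicity, read by MTT assay, with a stated time of 72 h (a lower number here means a stronger inhibitor, a higher number a weaker inhibitor), three compounds sharing one core have been measured. Compound 1 `CN(C)Cc1ccc2nc(NC(=O)N/N=C/c3cn(Cc4ccccc4Cl)c4ccccc34)sc2c1` gives 1080 nM, and compound 2 `CN(C)Cc1ccc2nc(NC(=O)N/N=C/c3cn(Cc4ccc(C(C)(C)C)cc4)c4ccccc34)sc2c1` gives 1850 nM. Compound 3 `CC1CCN(Cc2ccc3nc(NC(=O)N/N=C/c4c[nH]c5ccccc45)sc3c2)CC1` gives 3580 nM, a number beyond the scatter of repeated measurements from that of compound 1 and higher than it, but within the scatter of the number for compound 2.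

Compound 4 `CN(C)Cc1ccc2nc(NC(=O)N/N=C/c3c[nH]c4ccccc34)sc2c1` has not yet been measured. It differs from compound 3 in one place: dimethylamino in place of 4-methylpiperidin-1-yl on a saturated chain carbon bound to an aromatic carbon. In words, this is dimethylamino in place of 4-methylpiperidin-1-yl on a saturated chain carbon bound to an aromatic carbon.

Among the compounds with values here, no measured pair isolates this exchange. Within the data shown here, the only single-place step, a 1.7-fold higher number from compound 1 to compound 2 (0.23 log units; within the scatter), lies within the scatter, and it concerns a different place, a saturated chain carbon bound to an aromatic nitrogen. Compounds 1 and 2 do carry dimethylamino, but they also differ from compound 3 at that second place, so their numbers cannot be credited to dimethylamino alone. The data therefore give no ground for a large change, and no step beyond the scatter is expected. The expected step in this assay is a 1.3-fold lower number from compound 3 to compound 4 (0.11 log units; within the scatter). For compound 4 the estimated value is 2800 nM, with an expected range from 1100 nM to 7000 nM.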

Compound 4, half-maximal inhibitory concentration: 3300 nM
Compound 4: the middle estimate sits 1.2-fold (0.07 log units) below what was measured, within the range that was stated.
By their numbers in this assay, from the lowest: compounds 1, 2, 4 and 3 (each within the scatter of the next, the first and the last beyond it).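

In this assay, within the data shown here, dimethylamino in place of 4-methylpiperidin-1-yl on a saturated chain carbon bound to an aromatic carbon gives a first direct reading of this exchange (a 1.1-fold lower number from compound 3 to compound 4 (0.04 log units; within the scatter)): with the indole-free wording set aside, a group of 3 heavy atoms and no ring stands in for one of 7 heavy atoms with a six-membered ring, and the two numbers stay within the scatter of each other.

Compound 4 also isolates the group on the aromatic nitrogen, with dimethylamino held fixed: hydrogen in place of 4-(tert-butyl)benzyl stays within the scatter (a 1.8-fold higher number from compound 2 to compound 4 (0.25 log units; within the scatter)), whereas hydrogen in place of 2-chlorobenzyl goes beyond it (a 3.1-fold higher number from compound 1 to compound 4 (0.49 log units; beyond the scatter)), leaving compound 1 with the lower number of that pair. No measurement shown gives a cause for these results.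

Going by these compounds, it remains open whether a morpholin-4-yl group or a primary amine on the same chain carbon would also stay within the scatter of these numbers. On these data alone, it is equally open how a plain benzyl group or a simple methyl on the aromatic nitrogen would compare with hydrogen and with the two substituted benzyl groups.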